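This account rests on a few compounds, and the source may have more. Where it says the series, first, only, none or still open, it means among the compounds named here.

Measured compounds and their values:

Compound 1, `COc1ccc(Nc2nc3ccccc3nc2S(=O)(=O)c2ccccc2)cc1`: 640 nM
Compound 2, `COc1cc(Nc2nc3ccccc3nc2S(=O)(=O)c2ccccc2)cc(OC)c1`: 50 nM
Compound 3, `COc1ccc(Nc2nc3ccccc3nc2S(=O)(=O)c2ccc(Br)cc2)cc1`: 1190 nM

All three share one core, and each was tested in a functional assay on HL-60 cells (Homo sapiens) for cytotoxicity, read by MTT assay, with a stated time of 72 h; a lower number here means a stronger inhibitor, a higher number a weaker inhibitor. In this assay compound 1 gives 640 nM, while compound 2 gives 50 nM. The two differ in a single place, (3,5-dimethoxyphenyl in place of 4-methoxyphenyl on a nitrogen on an aromatic ring), and that change made a step of a 13-fold lower number from compound 1 to compound 2 (1.11 log units; beyond the scatter). Compound 3 gives 1190 nM in this assay; it differs from compound 1 by bromo in place of hydrogen on an aromatic carbon, a step of a 1.9-fold higher number from compound 1 to compound 3 (0.27 log units; within the scatter), so the values of compound 1 and compound 3 cannot be told apart here.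

Compound 4, `COc1cc(Nc2nc3ccccc3nc2S(=O)(=O)c2ccc(Br)cc2)cc(OC)c1`, has not been measured in this assay. It differs from compound 3 by 3,5-dimethoxyphenyl in place of 4-methoxyphenyl on a nitrogen on an aromatic ring. This is the same change that leads from compound 1 to compound 2, made on a core that differs from that of compound 1 only by the bromo group described above. Going by the values given here, with two examples of the change, there is no way to tell whether the bromo group alters its effect; the only guide is the earlier step, a 13-fold lower number from compound 1 to compound 2 (1.11 log units; beyond the scatter), together with the fact that the bromo group itself made a step within the scatter.

On that basis the step from compound 3 to compound 4 in this assay is expected to be close to the earlier one, about a 13-fold lower number from compound 3 to compound 4 (1.12 log units; beyond the scatter). Compound 4 is therefore estimated at 90 nM in this assay, with a plausible range from 30 nM to 280 nM.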

Compound 4, half-maximal inhibitory concentration: 2540 nM
Estimate against measurement, compound 4: 28-fold (1.45 log units) below; measured number above the stated range.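

In this assay, the change from 4-methoxyphenyl to 3,5-dimethoxyphenyl did not carry over from one core to the other: on the bromo core it gave a 2.1-fold higher number from compound 3 to compound 4 (0.33 log units; beyond the scatter), so the two results for this one change differ in size and point in opposite directions: the same change on two cores in this assay, a 13-fold lower number (1.11 log units; beyond the scatter) from compound 1 to compound 2 and a 2.1-fold higher number (0.33 log units; beyond the scatter) from compound 3 to compound 4, 27-fold (1.44 log units) apart, beyond the scatter of two such steps Seen from the other side, the bromo group gave a 51-fold higher number from compound 2 to compound 4 (1.71 log units; beyond the scatter), although its step on the core of compound 1 was within the scatter: the same change on two cores in this assay, a 1.9-fold higher number (0.27 log units; within the scatter) from compound 1 to compound 3 and a 51-fold higher number (1.71 log units; beyond the scatter) from compound 2 to compound 4, 27-fold (1.44 log units) apart, beyond the scatter of two such steps The two changes therefore do not simply add up in these four compounds, and the step seen on one core was a poor guide to the other, but this single set of four does not show why, or whether the same would happen with any other pair of groups.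

The compounds shown leave open whether fluoro, chloro or methyl in place of bromo would also remove the low number of compound 2. They also leave open how a phenyl ring carrying an amine or hydroxy groups in place of the methoxy groups would behave on either core.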